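A few compounds are considered here, and "the series" means these few. Any claim that something is new, unique, unknown or untested is made for them only; others in the source may bear on it.

Compound 2 `O=C(CSc1nc2ccc(NC(=O)c3ccc(Cl)cc3)cc2s1)NCc1ccc(Cl)cc1` carries the shared core with an amide to a 4-chlorobenzyl group at one end and a 4-chlorophenyl on a carbonyl carbon at the other. Among the measured compounds shown here, in a functional assay on HepG2 cells (Homo sapiens) for cytotoxicity, read by MTT assay, with a stated time of 48 h (on this read-out higher numbers stand for weaker inhibition and lower numbers for stronger inhibition), compound 2 gives 17800 nM, the highest of the three numbers measured so far. Compound 1 `COc1ccc(CNC(=O)CSc2nc3ccc(NC(=O)c4ccccc4)cc3s2)cc1` gives 12700 nM, which sits within the usual scatter of the number for compound 2, so the two cannot be ranked. For the measured compounds named here, compound 3 `O=C(CSc1nc2ccc(NC(=O)CCl)cc2s1)NCc1ccc(Cl)cc1` gives 1800 nM, and the only measured step, a 9.9-fold lower number from compound 2 to compound 3 (1.00 log units; beyond the scatter), follows from chloromethyl in place of 4-chlorophenyl on a carbonyl carbon.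

Compound 4 `O=C(CSc1nc2ccc(NC(=O)c3ccc(Cl)cc3)cc2s1)NCc1ccccc1` differs from compound 2 at a different site: hydrogen in place of chloro on an aromatic carbon. The change sits on the six-membered aromatic ring of carbon only, para to a large group, so that 4-chlorobenzyl becomes benzyl. Going by the values given here, no measured step touches this ring. Among the compounds with values here, the one step that is known concerns the other end of the molecule and offers no guidance here, and compounds 1 and 2, which differ at both ends at once, show numbers within the scatter of each other. The expectation is therefore a step of a 1.1-fold lower number from compound 2 to compound 4 (0.05 log units; within the scatter), which is expected to stay within the scatter. Compound 4 is estimated at 16000 nM, with a range from 6000 nM to 45000 nM.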

Compound 4, half-maximal inhibitory concentration: 25400 nM
The estimate for compound 4 lay 1.6-fold (0.20 log units) below the measured number, within the range that was stated.
By their numbers in this assay, from the lowest: compound 3; then compounds 1, 2 and 4 (each within the scatter of the next).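

With this step, the benzyl end of the molecule gets its first direct test: in this assay, hydrogen in place of chloro on the six-membered aromatic ring gives a 1.4-fold higher number from compound 2 to compound 4 (0.15 log units; within the scatter), so the numbers for these two compounds cannot be told apart. The chloro, which sits para to a large group, can therefore be exchanged for hydrogen here with no readable effect on this read-out, at least while a 4-chlorophenyl stays on the carbonyl carbon at the other end. Among the compounds shown here, that is a clear contrast with the only other single-site step, a 9.9-fold lower number from compound 2 to compound 3 (1.00 log units; beyond the scatter), which lies beyond the scatter and places the one readable difference so far at that other end, while no other kind of measurement is available to explain either result.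

From the compounds shown here alone, only chloro and hydrogen have been compared at this position on a matched pair, so the effect of a larger or charged group, such as a carboxylic acid or an amine, remains open. Going by these compounds, it is also open whether hydrogen and chloro would remain equally hard to separate on the benzyl end when chloromethyl, as in compound 3, stands on the carbonyl carbon.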